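This account rests on a few compounds, and the source may have more. Where it says the series, first, only, none or still open, it means among the compounds named here.

In a functional assay on MCF7 cells (Homo sapiens) for antiproliferative activity, read by MTT assay, with a stated time of 24 h (on this read-out higher numbers stand for weaker inhibition and lower numbers for stronger inhibition), compound 1 `CCn1c(C(=O)N[C@H](C)CO)ccc1C(CC)(CC)c1ccc(OCS(=O)(=O)c2ccccc2)c(C)c1` gives 10600 nM, and compound 2 `CCn1c(C(=O)N[C@@H](CO)C(C)C)ccc1C(CC)(CC)c1ccc(OCS(=O)(=O)c2ccccc2)c(C)c1` gives 18800 nM. The step of a 1.8-fold higher number from compound 1 to compound 2 (0.25 log units; within the scatter) is within the scatter, so on these two numbers compound 2 cannot be told apart from compound 1. Compound 3 `CCn1c(C(=O)NC2(C(=O)O)CC2)ccc1C(CC)(CC)c1ccc(OCS(=O)(=O)c2ccccc2)c(C)c1` differs from compound 2 by 1-carboxycyclopropyl in place of 1-(hydroxymethyl)-2-methylpropyl on an amide-type nitrogen. Going by the values given here, the only measured step also alters the group on the amide-type nitrogen and stays within the scatter; nothing measured bears on the 1-carboxycyclopropyl group itself. The step to compound 3 is therefore expected to be a 1.1-fold higher number from compound 2 to compound 3 (0.03 log units; within the scatter), not beyond the scatter. Compound 3 is estimated at 20000 nM in this assay, ranging from 7000 nM to 55000 nM.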

Compound 3, half-maximal inhibitory concentration: 41200 nM
For compound 3 the middle estimate is 2.1-fold (0.31 log units) below the measured one, and the stated range covers the measured number.
By their numbers in this assay, from the lowest: compounds 1 and 2 (each within the scatter of the next); then compound 3.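

In this assay, the group on the amide-type nitrogen now shows a change beyond the scatter. With 1-carboxycyclopropyl there, the number rises by a 2.2-fold higher number from compound 2 to compound 3 (0.34 log units; beyond the scatter) and by a 3.9-fold higher number from compound 1 to compound 3 (0.59 log units; beyond the scatter), both modest weakenings, which the exchange of methyl for isopropyl did not show. Nothing available here accounts for this shift.

On these data alone, the carboxylic acid and the three-membered ring enter together, so their separate contributions stay unknown. A 1-(hydroxymethyl)cyclopropyl group or an open-chain carboxylic acid in this place would tell them apart.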